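Methylating the phenolic hydroxy of an oxindole

The source may hold more compounds than are shown below. What is called first, only, known or untested is meant among the compounds shown, and "the series" means these compounds.

Measured compounds:
compound 1 `COc1cc2c(/C=C3/C(=O)Nc4ccc(O)cc43)c(Cl)n(Cc3cc(OC)c(OC)c(OC)c3)c2cc1C`, 1450 nM in a functional assay on cells (Melanoma cell, Homo sapiens) for cytotoxicity, with a stated time of 48 h; a lower number here means a stronger inhibitor of growth, a higher number a weaker inhibitor of growth
compound 2 `O=C1/C(=C/c2c(Cl)[nH]c3ccccc23)c2ccccc2N1Cc1ccccc1`, 5130 nM
compound 3 `COc1c(/C=C2/C(=O)Nc3ccccc32)c2ccccc2n1-c1ccccc1`, 1480 nM

Compound 1 gives the lowest number of the three in this assay. Compound 3 lies within the scatter of compound 1, while compound 2 gives a higher number than compound 1, beyond the scatter. Compound 4 `COc1ccc2c(c1)/C(=C\c1c(Cl)n(Cc3cc(OC)c(OC)c(OC)c3)c3cc(C)c(OC)cc13)C(=O)N2` differs from compound 1 by methyl in place of hydrogen on an oxygen on an aromatic ring. Among the compounds with values here, no measured pair shows this change, so its size is unknown here. Within the data shown here, nothing among the measured compounds points to a large effect of this change, so the step of a 1.2-fold higher number from compound 1 to compound 4 (0.09 log units; within the scatter) is expected to stay within the scatter. Compound 4 is accordingly estimated at 1800 nM, with a range from 700 nM to 4500 nM.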

Compound 4, concentration for 50% growth inhibition: 14800 nM
Estimate against measurement, compound 4: 8.2-fold (0.91 log units) below, and the stated range ends below it.
By their numbers in this assay, from the lowest: compounds 1 and 3 (each within the scatter of the next); then compound 2; then compound 4.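

In this assay, within the data shown here, this is the first measured step at this place, and hydroxy to methoxy gives a 10-fold higher number from compound 1 to compound 4 (1.01 log units; beyond the scatter) on an otherwise unchanged core. The position is therefore not indifferent to a single added methyl on the oxygen, and within this pair the free hydroxy goes with the lower number. No measured information given here accounts for the size of this step. The compounds shown leave open how an amine or an ethoxy group at this place would compare with hydroxy and methoxy. They also leave open whether the same change gives a step of similar size on another core.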